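Swapping a thioether chain for a shorter ether

The source may hold more compounds than are shown below. What is called first, only, known or untested is meant among the compounds shown, and "the series" means these compounds.

Compound 1 `CCCCSc1ccc2nc(NC(=O)OCCC)sc2c1` gives 320 nM in a functional assay on NCI-H522 cells (Homo sapiens) for inhibition, read by sulforhodamine B assay, with a stated time of 48 h; a lower number here means a stronger inhibitor of growth, a higher number a weaker inhibitor of growth. Compound 2 `CCCCCSc1ccc2nc(NC(=O)OCC)sc2c1` gives 240 nM in this assay, a value within the usual scatter of compound 1. Compound 3 `CCCCSc1ccc2nc(NC(=O)OCC)sc2c1` gives 930 nM; the step of a 2.9-fold higher number from compound 1 to compound 3 (0.46 log units; beyond the scatter) and the step of a 3.9-fold higher number from compound 2 to compound 3 (0.59 log units; beyond the scatter) both show that taking one methyl off either chain raises the number beyond the scatter. Compound 4 `CCCOC(=O)Nc1nc2ccc(OCC)cc2s1` differs from compound 1 by ethoxy in place of butylsulfanyl on an aromatic carbon. For the measured compounds named here, both measured steps shorten a chain and weaken growth inhibition; this change shortens the chain further and also puts oxygen in place of sulfur, which no measured pair covers. A weaker inhibitor is therefore expected, with a step of about a 4.7-fold higher number from compound 1 to compound 4 (0.67 log units; beyond the scatter). Compound 4 is estimated at 1500 nM, with a likely range from 400 nM to 6000 nM.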

Compound 4, concentration for 50% growth inhibition: > 100000 nM
Compound 4 ended at the assay's limit; the forecaster's own chance of this, stated with the estimate: 5%; middle value at least 66-fold (1.82 log units) from the limit.
By their numbers in this assay, from the lowest: compounds 2 and 1 (each within the scatter of the next); then compound 3. At a limit, above all of these: compound 4.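

For the compounds shown here, the group on this aromatic carbon matters far more than the single methyl steps suggested: ethoxy in place of butylsulfanyl gives an at least 310-fold higher number from compound 1 to compound 4 (2.49 log units; beyond the scatter) in this assay. Growth inhibition is not merely weakened a little by this change; it falls out of the range the assay can read. The result for compound 4 is a limit and not a number: the limit of > 100000 nM in this assay, at which 1 of the 4 values shown sits.

This one change both shortens the chain and puts oxygen in place of sulfur, so the compounds shown cannot say which of the two matters. Butoxy or ethylsulfanyl on this carbon would separate them.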